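Cytotoxicity notes on the fused pyridine series, compound 1 to 4

The source may report more compounds than this note shows. Statements on the series, on what has been measured and on what is new or still open speak of the compounds shown alone.

Compound 1 `CCCOC(=O)c1nc(C)c2c(c1N)C(=O)N(Cc1ccccc1)C2=O` is the reference point of the series. In an ADME assay on Vero cells (Chlorocebus sabaeus) for cytotoxicity, read by MTT assay (a higher number here means a weaker inhibitor, a lower number a stronger inhibitor), compound 1 gives "not determined" (no result reported), so no single number places it on the scale, and it stands only by the company of its neighbours. Within the data shown here, compound 2 `Cc1nnc(-c2nc(C)c3c(c2N)C(=O)N(Cc2ccccc2)C3=O)o1` is the one member with a result: in this assay compound 2 gives > 100000 nM, and this is a limit of the assay rather than a measured number. Compound 3 `Cc1nc(C(=O)NC#N)c(N)c2c1C(=O)N(Cc1ccccc1)C2=O` in this assay gives "not determined" (no result reported). Among the measured compounds shown here, the only evidence on the series is thus (the limit of > 100000 nM in this assay, at which 1 of the 3 values shown sits).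

The step to compound 4 `Cc1nc(-c2nc(C(F)(F)F)no2)c(N)c2c1C(=O)N(Cc1ccccc1)C2=O` changes compound 1 as follows: 3-(trifluoromethyl)-1,2,4-oxadiazol-5-yl in place of propoxycarbonyl on an aromatic carbon. For the measured compounds named here, no measured pair brackets this change, so the size of the step in this assay cannot be read from the data; the expectation is of no step beyond the scatter, with the new compound sitting where compound 2 already sits, at or near the limit.

On that basis compound 4 in this assay is expected at 80000 nM, estimated between 20000 nM and 200000 nM, with a fair chance that only a limit is reported.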

Compound 4, half-maximal inhibitory concentration: > 100000 nM
Compound 4 ended at the assay's limit; the forecaster's own chance of this, stated with the estimate: 55%; middle value at least 1.2-fold (0.09 log units) away from the limit.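

In this assay compound 4 gives > 100000 nM, which is a limit of the assay. Among these compounds, compound 2 also rests on a limit, so no step between compound 2 and compound 4 can be read. The compounds shown leave open whether 3-(trifluoromethyl)-1,2,4-oxadiazol-5-yl in place of 5-methyl-1,3,4-oxadiazol-2-yl shifts the value in this assay at all.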